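The compounds below may be only part of what the source reports. "The series", "measured", "known", "first", "only" and "open" are said of these compounds alone.

In an ADME assay on SH-SY5Y cells (Homo sapiens) for cytotoxicity, read by MTT assay, with a stated time of 72 h (on this read-out lower numbers stand for stronger inhibition and higher numbers for weaker inhibition), three compounds built on one shared core have been measured. Compound 1 `O=C(CN1CCN(C(=O)c2ccccc2)CC1)N1CCN(CCCc2c[nH]c3ccccc23)CC1` reaches only the limit of the assay, > 200000 nM, so that the limit of > 200000 nM in this assay, at which 1 of the 3 values shown sits, is all that is known of it. Compound 2 `O=C(CN1CCN(C(=O)c2ccccc2F)CC1)N1CCN(CCCc2c[nH]c3ccccc23)CC1` gives 82600 nM and compound 3 `O=C(CN1CCN(C(=O)c2ccccc2)CC1)N1CCN(CCCc2c[nH]c3ccc(F)cc23)CC1` gives 146000 nM; these two numbers lie within the usual scatter of each other. The step from compound 3 to compound 4 `O=C(CN1CCN(C(=O)c2cccc(F)c2)CC1)N1CCN(CCCc2c[nH]c3ccc(F)cc23)CC1` is fluoro in place of hydrogen on an aromatic carbon. Two measured steps share this kind of change: an at least 2.4-fold lower number from compound 1 to compound 2 (0.38 log units; beyond the scatter) and an at least 1.3-fold lower number from compound 1 to compound 3 (0.13 log units; that floor lies within the scatter). Both lean, if anywhere, towards a lower number, the first beyond the scatter and the second not. Compound 4 is therefore expected to show a modest lowering, a 1.8-fold lower number from compound 3 to compound 4 (0.26 log units; within the scatter), with an estimate of 80000 nM in a range of 30000 nM to 200000 nM.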

Compound 4, half-maximal inhibitory concentration: 169000 nM
The estimate for compound 4 lay 2.1-fold (0.32 log units) below the measured number; low and high end bracket the measured number.
By their numbers in this assay, from the lowest: compounds 2, 3 and 4 (each within the scatter of the next, the first and the last beyond it). At a limit, above all of these: compound 1.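

In this assay, phenyl to 3-fluorophenyl gives a 1.2-fold higher number from compound 3 to compound 4 (0.06 log units; within the scatter), so here the change brings no lowering that can be read. The same kind of change therefore does not read alike across the two steps: the same change on two cores in this assay, an at least 2.4-fold lower number (0.38 log units; beyond the scatter) from compound 1 to compound 2 and a 1.2-fold higher number (0.06 log units; within the scatter) from compound 3 to compound 4, at least 2.8-fold (0.44 log units) apart, beyond the scatter of two such steps. Compound 1, the starting point of the earlier step, gives only a limit, > 200000 nM.

Going by these compounds, whether the gap between the steps follows from the second fluoro on the core or from the different ring place of the fluoro in compound 2 stays open. So does the effect of an amine or a carboxylic acid at this position.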